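Replacing the methoxy group of compound 3

The source may hold more compounds than are shown below. What is called first, only, known or untested is meant among the compounds shown, and "the series" means these compounds.

Values measured so far in a functional assay on SW480 cells (Homo sapiens) for antiproliferative activity, read by MTT assay, with a stated time of 48 h (a higher number here means a weaker inhibitor, a lower number a stronger inhibitor), are these
compound 1 `CC(=O)OC/C1=C/C[C@](C)(CCC=C(C)C)/C=C/[C@@H](OC(=O)C=C(C)C)[C@](C)(OC(C)=O)/C=C/C1=O` gives 3520 nM
compound 2 `COC/C1=C/C[C@](C)(CCC=C(C)C)/C=C/[C@@H](OC(=O)C=C(C)C)[C@](C)(OC)/C=C/C1=O` gives 14600 nM
compound 3 `COC/C1=C/C[C@](C)(CCC=C(C)C)/C=C/[C@@H](OC(=O)C=C(C)C)[C@](C)(O)/C=C/C1=O` gives 3850 nM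
compound 4 `CC[Si](CC)(CC)C/C1=C/C[C@](C)(CCC=C(C)C)/C=C/[C@@H](OC(=O)C=C(C)C)[C@](C)(O)/C=C/C1=O` has no value yet

Compound 3 at 3850 nM lies within the scatter of compound 1 and well apart from compound 2. In compound 4 the change is a group of 7 heavy atoms (6 carbon, 1 silicon; no ring) in place of a group of 2 heavy atoms (1 carbon, 1 oxygen; no ring), on a saturated chain carbon bound to a double-bonded ring carbon and the rest of compound 3 stays. For the measured compounds named here, the one measured single-place step is a 3.8-fold lower number from compound 2 to compound 3 (0.58 log units; beyond the scatter) at a different place, so it bears only indirectly and says nothing about this carbon. Compound 3 differs from compound 1 at the changed place and at one other, and compound 1 at 3520 nM stays within the scatter of it, so a different group here need not move the number. Going by the values given here, no measured compound carries silicon, which leaves the direction open. The expected change is a 1.3-fold lower number from compound 3 to compound 4 (0.11 log units; within the scatter) and no step beyond the scatter is firmly expected, though the range is kept wide. The estimated value for compound 4 is 3000 nM with an expected range of 900 nM to 10000 nM in this series.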

Compound 4, half-maximal inhibitory concentration: 2690 nM
Estimate against measurement, compound 4: 1.1-fold (0.05 log units) above; measured number inside the range.
By their numbers in this assay, from the lowest: compounds 4, 1 and 3 (each within the scatter of the next); then compound 2.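

For the compounds shown here, on a saturated chain carbon bound to a double-bonded ring carbon, the methoxy group of compound 3 gives way to a far larger silicon-bearing group with no shift beyond the scatter in this assay as the exchange yields a 1.4-fold lower number from compound 3 to compound 4 (0.16 log units; within the scatter) and this is the only single-place reading at this carbon. The entering group has 0 hydrogen-bond acceptors against 1 for methoxy, so for this pair the number holds without an acceptor on this carbon. Nothing at hand gives a reason for this result.

Going by these compounds, whether an amine or a carboxylic acid on this carbon would also leave the number in place remains open. On these data alone, whether silicon itself matters also remains open, and an all-carbon chain of similar size in the same place would address that.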